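This account rests on a few compounds, and the source may have more. Where it says the series, first, only, none or still open, it means among the compounds named here.

Of the compounds shown here, three that share one core have been measured in a functional assay on HeLa cells (Homo sapiens) for antiproliferative activity, read by CCK-8 assay, with a stated time of 48 h; a lower number here means a stronger inhibitor, a higher number a weaker inhibitor. Compound 1 `CC(C)CSc1n[nH]c(-n2[se]c3ccccc3c2=O)n1` gives 34900 nM. Compound 2 `Cc1ccccc1CSc1n[nH]c(-n2[se]c3ccccc3c2=O)n1` gives 6130 nM, and compound 3 `O=c1c2ccccc2[se]n1-c1nc(SCc2ccc([N+](=O)[O-])cc2)n[nH]1` gives 3940 nM. Among these three numbers compound 2 stands second highest; its gap to compound 3 lies within the usual scatter of such measurements, while the step of a 5.7-fold lower number from compound 1 to compound 2 (0.76 log units; beyond the scatter) lies beyond it.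

Compound 4 `CCSc1n[nH]c(-n2[se]c3ccccc3c2=O)n1` has not yet been measured. It differs from compound 2 in one place: methyl in place of 2-methylphenyl on a saturated chain carbon bound to a sulfur. Going by the values given here, only one measured step bears on this position, namely a 5.7-fold lower number from compound 1 to compound 2 (0.76 log units; beyond the scatter), where a ring took the place of a branched chain and the number fell. The change to compound 4 runs the opposite way, with the ring leaving and a short chain entering, so the number is expected to rise again. Compound 1, which carries a chain in this place, gives 34900 nM, and compound 4 is expected to land near that region. The step from compound 2 to compound 4 is therefore expected to be a 6.5-fold higher number from compound 2 to compound 4 (0.81 log units; beyond the scatter). The estimate for compound 4 is 40000 nM, with a range from 12000 nM to 120000 nM.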

Compound 4, half-maximal inhibitory concentration: 14100 nM
Beside the measured number, compound 4's estimate is 2.8-fold (0.45 log units) above it, within the range that was stated.
By their numbers in this assay, from the lowest: compounds 3 and 2 (each within the scatter of the next); then compound 4; then compound 1.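

In this assay, the ring is not needed for every gain at this position: a 2.5-fold lower number from compound 1 to compound 4 (0.39 log units; beyond the scatter), with methyl replacing isopropyl on the saturated chain carbon bound to a sulfur, so two compounds with no ring there still differ beyond the scatter. There is also a 2.3-fold higher number from compound 2 to compound 4 (0.36 log units; beyond the scatter), which is a smaller step than a 5.7-fold lower number from compound 1 to compound 2 (0.76 log units; beyond the scatter), so the 2-methylphenyl group keeps an advantage, but over the short chain it is less than the comparison with isopropyl suggested. The three compounds therefore do not follow group size in a single direction, as compound 4, with the smallest group, falls between compound 2 and compound 1, and no supporting measurement is available to explain this order. A longer unbranched chain such as butyl, or a plain benzyl group without the methyl, would help show whether the branching in compound 1 or the length of the chain matters more here. Going by these compounds, how an amine or a carboxylic acid at the end of this chain would affect the number also remains open.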